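A Tetrazole Takes the Place of a Nitrile

The source may report more compounds than this note shows. Statements on the series, on what has been measured and on what is new or still open speak of the compounds shown alone.

Of the compounds shown here, three have been measured in an assay for inhibition of 17-beta-hydroxysteroid dehydrogenase type 2 (Homo sapiens), read by HPLC, with a stated time of 10 min, tested at 1 uM; on this read-out lower numbers stand for less inhibition and higher numbers for more inhibition at the one concentration tested (going by the name of the read-out). Compound 1 `O=C(c1ccc(F)c(O)c1)c1ccc2cc(O)ccc2n1` gives 71%. Compound 2 `C=C(c1ccc(F)c(O)c1)c1cccc(-c2cccc(O)c2F)n1` gives 100%. Compound 3 `N#Cc1ccc2ccc(C(=O)c3ccc(F)c(O)c3)nc2c1` gives 56%, the lowest of the three numbers. Its nearest neighbour on the read-out is compound 1, whose number is higher by an amount beyond the usual scatter, and the furthest is compound 2, higher still by a gap well beyond the scatter. No two of the measured compounds differ in just one place, so no single structural change can yet be tied to a change in the read-out.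

The next compound, compound 4 `O=C(c1ccc(F)c(O)c1)c1ccc2ccc(-c3nnn[nH]3)cc2n1`, differs from compound 3 in one spot: 1H-tetrazol-5-yl in place of cyano on an aromatic carbon. The nitrile of compound 3 is exchanged for a five-membered aromatic ring with four heteroatoms that brings one hydrogen-bond donor and three acceptors to the same aromatic carbon.

Nothing in the measured set shows what such an exchange does in this assay. The step from compound 3 to compound 4 is therefore expected to be small, a number 1 percentage points lower from compound 3 to compound 4 (within the scatter), with no clear direction and likely within the scatter. Compound 4 is estimated to give 55%, in a range from 30% to 80%.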

Compound 4, a percentage reported as inhibition, at one concentration (the size of the read-out at that concentration, not a potency): 52%
For compound 4 the middle estimate is 3 percentage points above the measured one; the range from low to high includes it.
By their numbers in this assay, from the lowest: compounds 4 and 3 (each within the scatter of the next); then compound 1; then compound 2.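

In this assay, for the compounds shown here, putting 1H-tetrazol-5-yl in place of cyano gives a number 4 percentage points lower from compound 3 to compound 4 (within the scatter) and so, for the first time in this set, ties a single structural change to the read-out. At this aromatic carbon, a cyano group with no ring and no hydrogen-bond donor and a five-membered aromatic ring with a hydrogen-bond donor give numbers that cannot be told apart at the one concentration tested, so the position accepts both groups in this test. Nothing measured here offers an explanation for this result.

Going by these compounds alone, only two groups have been compared at this position, so it remains open whether a carboxylic acid, an amine or a plain hydrogen on the same aromatic carbon would also give a number within the scatter of these two. On these data alone, a reading at a single concentration is also not a potency, so compound 3 and compound 4 could still differ across a wider range of concentrations, and the effect of this exchange on other parts of the shared core remains unknown.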